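Hydantoin nitrogen substituents on a spiro-cyclopropane quinoline series

The source may report more compounds than this note shows. Statements on the series, on what has been measured and on what is new or still open speak of the compounds shown alone.

Measured compounds in a functional assay on the whole organism (strain Kunming) with Mus musculus as the target, in the maximal electroshock model, with a stated time of 0.5 h; on this read-out lower numbers stand for an effect already at smaller amounts and higher numbers for an effect only at larger amounts of compound:
- compound 1 `CCC(CO)N1C(=O)NC2(CC2c2ccc3cccc(OCc4ccccc4)c3n2)C1=O` gives 30 mg/kg
- compound 2 `O=C1NC2(CC2c2ccc3cccc(OCc4ccccc4)c3n2)C(=O)N1c1ccc(Cl)cc1` gives 300 mg/kg
- compound 3 `COc1ccc(N2C(=O)NC3(CC3c3ccc4cccc(OCc5ccccc5)c4n3)C2=O)cc1` gives 30 mg/kg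

Compound 1 stands level with compound 3 at the digits printed, and together the two hold the lowest of the three numbers in this assay. Its furthest neighbour is compound 2, a step of a 10-fold higher number from compound 1 to compound 2 (1.00 log units; beyond the scatter) that lies beyond the scatter. Compound 3 sits at no change at the digits printed from compound 1 to compound 3 (within the scatter), within the scatter of compound 1, and the step of a 10-fold lower number from compound 2 to compound 3 (1.00 log units; beyond the scatter) shows that the two aryl groups on the ring nitrogen of the shared core are not equivalent.

Compound 4 `O=C1NC2(CC2c2ccc3cccc(OCc4ccccc4)c3n2)C(=O)N1c1ccc(C(F)(F)F)cc1` is the next member. Relative to compound 1 the change is 4-(trifluoromethyl)phenyl in place of 1-(hydroxymethyl)propyl on an amide-type nitrogen in a ring.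

For the measured compounds named here, the steps that bear on it are the two aryl-for-alkyl replacements: the chloro case, a 10-fold higher number from compound 1 to compound 2 (1.00 log units; beyond the scatter), and the methoxy case, no change at the digits printed from compound 1 to compound 3 (within the scatter). Going by the values given here, no step involving a trifluoromethyl group has been measured in this assay, so the outcome is bracketed by those two. Compound 4 is expected to give a somewhat higher number in this assay, a 3.3-fold higher number from compound 1 to compound 4 (0.52 log units; beyond the scatter), with the estimate for compound 4 at 100 mg/kg and a range from 30 mg/kg to 300 mg/kg.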

Compound 4, minimum effective dose: 300 mg/kg
Estimate against measurement, compound 4: 3.0-fold (0.48 log units) below; the range from low to high includes it.
By their numbers in this assay, from the lowest: compounds 1 and 3 (each within the scatter of the next); then compounds 2 and 4 (each within the scatter of the next).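

In this assay, the 4-(trifluoromethyl)phenyl group on the amide-type ring nitrogen gives the same outcome as the 4-chlorophenyl group, with no change at the digits printed from compound 2 to compound 4 (within the scatter), and the swap of trifluoromethyl for chloro on the aromatic carbon therefore registers no difference at this read-out. Replacing 1-(hydroxymethyl)propyl with this aryl group gives a 10-fold higher number from compound 1 to compound 4 (1.00 log units; beyond the scatter), and replacing methoxy with trifluoromethyl on the same aromatic carbon gives a 10-fold higher number from compound 3 to compound 4 (1.00 log units; beyond the scatter), so a second case now shows that an aryl group at this nitrogen does not by itself hold the number of compound 1. Among the three aryl compounds, compounds 2 and 4 form one pair and compound 3 alone stays level with compound 1, so the substituent on the phenyl ring matters here, and no measurement on hand accounts for the split.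

From the compounds shown here alone, whether compound 3 is a lone case or part of a wider trend stays open, and an unsubstituted phenyl or a 4-aminophenyl group on the same nitrogen would bear on that. Going by these compounds, the role of the hydroxyl in the alkyl group of compound 1 is equally open, and a plain butyl chain or a longer hydroxyalkyl chain at this nitrogen would address it.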